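The source may hold more compounds than are shown below. What is called first, only, known or untested is meant among the compounds shown, and "the series" means these compounds.

In an ADME assay on HEK293 cells (Homo sapiens) for cytotoxicity, read by MTT assay, with a stated time of 3 days (on this read-out higher numbers stand for weaker inhibition and lower numbers for stronger inhibition), compound 1 (`COc1ccccc1-c1cccc(O)c1`) gives 50 ug/mL and sits at the weak end of the three measured compounds. Compound 3 (`COc1cccc(-c2ccc(O)cc2)c1`) gives 35 ug/mL and lies within the usual scatter of compound 1. Compound 2 (`Nc1ccccc1-c1cccc(O)c1`) gives 10.5 ug/mL and is the one clear departure. It carries amino in place of methoxy on an aromatic carbon, which brings a 4.8-fold lower number from compound 1 to compound 2 (0.68 log units; beyond the scatter) as a modest step and the only measured one. Compound 4 (`COc1ccc(-c2cccc(O)c2)c(OC)c1`) has not been measured yet and differs from compound 1 by methoxy in place of hydrogen on an aromatic carbon and so gains a methoxy group. Among the compounds with values here, no measured step adds a methoxy group, so the amino step bears on this change only loosely. It shows that the number can move with a single group, but not which way it moves with this one. A small shift toward stronger inhibition in this assay seems the safest expectation, with nothing firmly expected beyond the scatter. The expected result is a 1.3-fold lower number from compound 1 to compound 4 (0.10 log units; within the scatter) on this reasoning. Compound 4 is estimated at 40 ug/mL with an expected range from 18 ug/mL to 90 ug/mL in this assay.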

Compound 4, half-maximal inhibitory concentration: 28 ug/mL
Beside the measured number, compound 4's estimate is 1.4-fold (0.15 log units) above it, within the range that was stated.
By their numbers in this assay, from the lowest: compound 2; then compounds 4, 3 and 1 (each within the scatter of the next).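

Placing a methoxy group on this aromatic carbon, meta to a methoxy group and para to a group of 7 heavy atoms, gives a 1.8-fold lower number from compound 1 to compound 4 (0.25 log units; within the scatter) in this assay. Within the data shown here, this is the first measured look at a change at this position, and it shows that the added methoxy group does not move the number beyond the usual variation between repeats, whereas the earlier swap of methoxy for amino gave a 4.8-fold lower number from compound 1 to compound 2 (0.68 log units; beyond the scatter). Nothing measured here explains why this addition leaves the number within the scatter.

From the compounds shown here alone, whether an amine, a carboxylic acid or a fluorine at this same position would shift the number remains open. Going by these compounds, it also remains open whether a methoxy group at this position would behave the same way on compound 2, which carries the amino group.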